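The source may hold more compounds than are shown below. What is called first, only, known or untested is meant among the compounds shown, and "the series" means these compounds.

Compound 1 `O=C(Nc1cccc2cccnc12)c1ncccn1` is the parent amide. In a functional assay on PANC-1 cells (Homo sapiens) for inhibition, read by MTT assay, with a stated time of 72 h (on this read-out higher numbers stand for weaker inhibition and lower numbers for stronger inhibition), compound 1 gives only a limit, > 10000 nM, which sits at the limit of > 10000 nM in this assay, at which 1 of the 2 values shown sits. Compound 2 `O=C(Nc1cc(F)cc2cccnc12)c1ncccn1` carries fluoro in place of hydrogen on an aromatic carbon, and in this assay compound 2 gives 5300 nM, the only number shown among these values. Among the compounds with values here, the single measured step, an at least 1.8-fold lower number from compound 1 to compound 2 (0.27 log units; that floor lies within the scatter), rests on that limit and does not clear the scatter. Compound 3 `O=C(Nc1cc(Cl)cc2cccnc12)c1ncccn1` differs from compound 2 by chloro in place of fluoro on an aromatic carbon. With so slight a precedent, compound 3 is expected to give 4000 nM, between 1500 nM and 12000 nM, so that a 1.3-fold lower number from compound 2 to compound 3 (0.12 log units; within the scatter) means no expected step beyond the scatter.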

Compound 3, half-maximal inhibitory concentration: 4670 nM
The estimate for compound 3 lay 1.2-fold (0.07 log units) below the measured number, within the range that was stated.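

In this assay, chloro in place of fluoro at this position gives a 1.1-fold lower number from compound 2 to compound 3 (0.05 log units; within the scatter), so the two halogens cannot be told apart here. Chloro in place of hydrogen gives an at least 2.1-fold lower number from compound 1 to compound 3 (0.33 log units; beyond the scatter), the first step at this position to clear the scatter, though its size is only a floor. Compound 1 stays a limit rather than a number: the limit of > 10000 nM in this assay, at which 1 of the 3 values shown sits. On these data alone, whether a group other than a halogen at this position, such as an amine or a methoxy group, would give a larger step remains open, as does how either halogen behaves on other cell lines.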